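The compounds below may be only part of what the source reports. "The series", "measured", "known", "first", "only" and "open" are said of these compounds alone.

Working notes on the series.

Compound 1, `COc1cc(-n2cnc3ccc(-c4cccc(N)c4)cc32)cc(OC)c1OC`, gives 21 nM in a functional assay on SGC-7901 cells (Homo sapiens) for antiproliferative activity, read by MTT assay, with a stated time of 72 h; a lower number here means a stronger inhibitor, a higher number a weaker inhibitor. Compound 2, `COc1cccc(-c2ccc3ncn(-c4cc(OC)c(OC)c(OC)c4)c3c2)c1`, gives 3310 nM in the same assay. Compound 3, `COc1cc(-n2cnc3ccc(-c4ccc(O)cc4)cc32)cc(OC)c1OC`, reaches only the limit of the assay, > 10000 nM, so no number is known for it; it is the compound behind (the limit of > 10000 nM in this assay, at which 1 of the 3 values shown sits). On what has been measured, compound 3 stands at the weak end: an at least 470-fold higher number from compound 1 to compound 3 (2.67 log units; beyond the scatter), and an at least 3.0-fold higher number from compound 2 to compound 3 (0.48 log units; beyond the scatter). The other step, a 160-fold higher number from compound 1 to compound 2 (2.20 log units; beyond the scatter), shows how much the pendant phenyl substituent moves this assay within the shared core.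

Compound 4, `COc1cc(-n2cnc3ccc(-c4ccc(C(C)=O)cc4)cc32)cc(OC)c1OC`, is not yet measured. Its difference from compound 3 is acetyl in place of hydroxy on an aromatic carbon, on the same aromatic carbon, para to a large group. No measured step tests an acetyl on this ring; the three steps shown concern amino, methoxy and hydroxy only, and all are beyond the scatter. They say the series is sensitive to this substituent but give no direction for an acetyl. Since compound 3 is only a limit, the estimate for compound 4 is wide: a step of an at least 2.0-fold lower number from compound 3 to compound 4 (0.30 log units; that floor lies within the scatter) is expected, and compound 4 is estimated at 5000 nM, between 800 nM and 20000 nM, with a real chance the assay again returns a limit.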

Compound 4, half-maximal inhibitory concentration: 450 nM
Compound 4: middle estimate off by 11-fold (1.05 log units), on the high side; the measured number lies below the stated range.
By their numbers in this assay, from the lowest: compound 1; then compound 4; then compound 2. At a limit, above all of these: compound 3.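

Acetyl in place of hydroxy on the aromatic carbon para to a large group changes the result sharply in this assay, with an at least 22-fold lower number from compound 3 to compound 4 (1.34 log units; beyond the scatter), showing that this carbon can carry a group and keep measurable activity, which compound 3 alone could not show. As far as these compounds go, compound 3 stands only at a limit of the assay, so this step is a floor and its true size is unknown: the limit of > 10000 nM in this assay, at which 1 of the 4 values shown sits. The 4-acetylphenyl group also improves on the 3-methoxyphenyl group, with a 7.4-fold lower number from compound 2 to compound 4 (0.87 log units; beyond the scatter), but falls short of the 3-aminophenyl group, with a 21-fold higher number from compound 1 to compound 4 (1.33 log units; beyond the scatter), which places it in the middle of the measured groups.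

The steps from compound 1 and compound 2 to compound 4 change the group and its place on the ring together, which leaves the share of each in those steps open. Also open, from the compounds shown here alone, is how a carboxylic acid, an amide or a longer ketone chain on the same aromatic carbon would compare with the acetyl.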